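The compounds below may be only part of what the source reports. "The series", "measured", "known", "first", "only" and "open" are said of these compounds alone.

Measured compounds:
compound 1 `CCN1CCc2c(sc(NC(=O)Nc3ccc(Cl)cc3)c2C(=O)c2nnco2)C1` — > 25000 nM
compound 2 `NC(=O)c1c(NC(=O)Nc2ccc(Cl)cc2)sc2c1CCN(CC1CCCC1)C2` — 1830 nM

This account follows the step from compound 1 to compound 3. In a functional assay (strain AB) with Danio rerio as the target, read by microscopy, with a stated time of 1 h (on this read-out lower numbers stand for an effect already at smaller amounts and higher numbers for an effect only at larger amounts of compound), compound 1 gives only a limit, > 25000 nM, and no number. Compound 2 differs from compound 1 in several places; in this assay compound 2 gives 1830 nM. The two values show that compound 2 produces an effect within the measured range while compound 1 does not. Compound 1 thus sits at the limit, (the limit of > 25000 nM in this assay, at which 1 of the 2 values shown sits).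

Compound 3 `CCN1CCc2c(sc(NC(=O)Nc3ccc(Cl)cc3)c2C(=O)NC2COC2)C1` is not yet measured in this assay. It differs from compound 1 in one place: (oxetan-3-yl)amino in place of 1,3,4-oxadiazol-2-yl on a carbonyl carbon. Compound 2 also carries an amide on the carbonyl carbon, and its value is the only measured point on that side. For compound 3 the expectation is a step toward lower numbers from compound 1, an at least 5.0-fold lower number from compound 1 to compound 3 (0.69 log units; beyond the scatter), larger than the scatter. The estimated value for compound 3 in this assay is 5000 nM, with a range from 1500 nM to 25000 nM.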

Compound 3, half-maximal effective concentration: > 25000 nM
Compound 3 gave a limit, no number (the forecaster's own chance of this, stated with the estimate: 30%); middle value at least 5.0-fold (0.69 log units) from the limit.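

In this assay compound 3 gives > 25000 nM as a limit and not a number. Among these compounds, compound 1 also stands at a limit, so no step between compound 1 and compound 3 can be read. Still open, as far as these compounds go, is whether (oxetan-3-yl)amino in place of 1,3,4-oxadiazol-2-yl on a carbonyl carbon changes the read-out at all.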